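The source may report more compounds than this note shows. Statements on the series, on what has been measured and on what is new or still open speak of the compounds shown alone.

Measured compounds:
compound 1, `CC(C)(C)c1ccc(NC(=O)N2CCN(c3nncc4ccccc34)CC2)cc1`, > 10000 nM (a limit)
compound 2, `CC(C)c1ccc(NC(=O)N2CCN(c3nncc4ccccc34)CC2)cc1`, > 10000 nM (a limit)

In an assay on HEK293 cells for inhibition of transient receptor potential cation channel subfamily V member 1 (Homo sapiens), read by FLIPR, at pH 5.5 (a higher number here means a weaker inhibitor, a lower number a stronger inhibitor), compound 1 gives > 10000 nM, which is a limit of the assay rather than a number. In this assay compound 2 gives > 10000 nM, again a limit and not a number. Compound 2 therefore stands at the edge of what the assay can report, and a step that the two limits leave unreadable from compound 1 to compound 2 cannot be read. The whole of the evidence so far is the limit of > 10000 nM in this assay, at which 2 of the 2 values shown sit. Compound 3, `O=C(Nc1ccc(C(F)(F)F)cc1)N1CCN(c2nncc3ccccc23)CC1`, has not yet been measured; it differs from compound 2 by trifluoromethyl in place of isopropyl on an aromatic carbon. Among the measured compounds shown here, no measured step bears directly on this change, and the only recorded step is itself unreadable, so neither a direction nor a size can be taken from the data. Compound 3 is expected to remain near the same limit, which means an expected step that the limit leaves unreadable from compound 2 to compound 3. In this assay the estimate for compound 3 is 15000 nM, with an expected range from 3000 nM to 100000 nM.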

Compound 3, half-maximal inhibitory concentration: > 10000 nM
Compound 3: no number, only a limit; the forecaster's own chance of this, stated with the estimate: 75%; the middle value does not contradict the limit.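

In this assay, among the compounds shown here, compound 3 gives > 10000 nM, which is a limit and not a number, so no step among compound 1, compound 2 and compound 3 can be read. The compounds shown leave open whether swapping this one group changes inhibition at all.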